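This account rests on a few compounds, and the source may have more. Where it says the series, first, only, none or still open, it means among the compounds named here.

Among the measured compounds shown here, compound 2 `COc1ccc(-c2nc(N)c3nn(-c4ccccc4)cc3n2)cc1` gives 33 nM in an assay on CHO cells for displacement of a labelled ligand from adenosine receptor A3 (Homo sapiens), read by scintillation counting, with a stated time of 60 min (on this read-out higher numbers stand for weaker inhibition and lower numbers for stronger inhibition), the higher of the two numbers measured so far. Compound 1 `Nc1nc(-c2cccs2)nc2cn(-c3ccccc3)nc12` gives 9.7 nM in this assay. For the measured compounds named here, the only step between them is a 3.4-fold higher number from compound 1 to compound 2 (0.53 log units; beyond the scatter), a swap at an aromatic carbon. Compound 3 `COc1ccc(-c2nc(NC(=O)c3ccncc3)c3nn(-c4ccccc4)cc3n2)cc1` differs from compound 2 by (pyridin-4-yl)carbonyl in place of hydrogen on a nitrogen on an aromatic ring. Going by the values given here, that change sits on the amino nitrogen, which no measured step touches, so the step from compound 1 to compound 2 does not bear on it. A modest gain is nonetheless expected, namely a 1.7-fold lower number from compound 2 to compound 3 (0.22 log units; within the scatter). Compound 3 is therefore estimated at 20 nM, within 4 nM to 100 nM.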

Compound 3, inhibition constant: 9.83 nM
The estimate for compound 3 lay 2.0-fold (0.31 log units) above the measured number; the measured number falls inside the stated range.
By their numbers in this assay, from the lowest: compounds 1 and 3 (each within the scatter of the next); then compound 2.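

Among the compounds shown here, compound 3 is the first compound changed on the amino nitrogen, and in this assay the swap of amino to ((pyridin-4-yl)carbonyl)amino gives a 3.4-fold lower number from compound 2 to compound 3 (0.53 log units; beyond the scatter) on the 4-methoxyphenyl series. This nitrogen can therefore carry the (pyridin-4-yl)carbonyl group with a modest gain rather than a loss. Nothing available explains this gain.

On these data alone, it remains open whether the gain needs the pyridine ring or only the carbonyl, which a benzoyl or acetyl group on this nitrogen would separate. Also open, as far as these compounds go, is whether the same change would have a similar effect with the thiophen-2-yl group of compound 1 in place of 4-methoxyphenyl.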